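The source may report more compounds than this note shows. Statements on the series, on what has been measured and on what is new or still open speak of the compounds shown alone.

Measured compounds and their values in a functional assay on A549 cells (Homo sapiens) for inhibition; on this read-out higher numbers stand for weaker inhibition and lower numbers for stronger inhibition:

compound 1, `N#CC1CN1C(=O)NCc1ccccc1`, 7400 nM

compound 2, `N#CC1CN1C(=O)Nc1ccc(S(N)(=O)=O)cc1`, a limit of the assay rather than a number, > 38000 nM

compound 3, `N#CC1CN1C(=O)Nc1ccc([N+](=O)[O-])cc1`, 3900 nM

Compound 3 has the lowest of the two numbers; compound 1 sits within the usual scatter of it, so no order between the two can be claimed. The value of compound 2 is only a limit.

Compound 4, `N#CC1CN1C(=O)Nc1ccc(F)cc1`, has not yet been measured. It differs from compound 3 in one place: fluoro in place of nitro on an aromatic carbon.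

Only one measured step is shown, an at least 9.7-fold lower number from compound 2 to compound 3 (0.98 log units; beyond the scatter), and it concerns sulfamoyl and nitro, not fluoro. It therefore does not bear directly on the change to compound 4; the evidence the limit of > 38000 nM in this assay, at which 1 of the 3 values shown sits, only tells that a sulfamoyl group sits at the limit. For the measured compounds named here, with no step involving fluoro, the expectation rests on compound 3 alone. The estimated step for compound 4 is a 2.1-fold higher number from compound 3 to compound 4 (0.31 log units; beyond the scatter), a rise of the number, at most modest and possibly within the scatter. Compound 4 is therefore expected to give about 8000 nM, in a range from 2500 nM to 30000 nM.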

Compound 4, half-maximal inhibitory concentration: 6200 nM
The estimate for compound 4 lay 1.3-fold (0.11 log units) above the measured number, within the range that was stated.
By their numbers in this assay, from the lowest: compounds 3, 4 and 1 (each within the scatter of the next). At a limit, above all of these: compound 2.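

Exchanging nitro for fluoro on this aromatic carbon gives a 1.6-fold higher number from compound 3 to compound 4 (0.20 log units; within the scatter), so in this assay the two groups cannot be ranked, even though a single heavy atom with 0 hydrogen-bond acceptors replaces 3 heavy atoms with 2 hydrogen-bond acceptors. Nitro is therefore not required at this position for a number in this range, and the exchange of sulfamoyl for fluoro reads an at least 6.1-fold lower number from compound 2 to compound 4 (0.78 log units; beyond the scatter), so sulfamoyl now differs from two other groups here. Compound 2 still gives a limit of the assay rather than a number: the limit of > 38000 nM in this assay, at which 1 of the 4 values shown sits.

As far as these compounds go, it remains open whether an amine, a carboxylic acid or a longer chain at this position would shift the number in either direction. The compounds also cannot show what the nitrile contributes, since all of them carry it on the shared core.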